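This account rests on a few compounds, and the source may have more. Where it says the series, first, only, none or still open, it means among the compounds named here.

Measured compounds:
compound 1, `Nc1nc(O)c2nnn(C3C=CC(CO)C3)c2n1`: 4.5 ug/mL in a functional assay on P388 cells (Mus musculus) for inhibition; on this read-out lower numbers stand for an effect already at smaller amounts and higher numbers for an effect only at larger amounts of compound
compound 2, `Nc1nc(O)c2nnn(C3CCC(CO)C3)c2n1`: 51 ug/mL in this assay
compound 3, `Nc1nc(N)c2nnn(C3C=CC(CO)C3)c2n1`: > 100 ug/mL in this assay, a limit of the assay and not a number

Of the compounds shown here, three have been measured in this assay. Compound 1 gives 4.5 ug/mL, while compound 2 gives 51 ug/mL, the highest of the two numbers; the two share no single counted difference, and how their cores differ is not broken down here. Compound 3 sits at a limit of the assay, > 100 ug/mL. Compound 3 arises from compound 1 by the change (amino in place of hydroxy on an aromatic carbon), and this brought an at least 22-fold higher number from compound 1 to compound 3 (1.34 log units; beyond the scatter); the result rests on (the limit of > 100 ug/mL in this assay, at which 1 of the 3 values shown sits), so only the lower bound of the step is known.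

The unmeasured compound 4, `Nc1nc(N)c2nnn(C3CCC(CO)C3)c2n1`, arises from compound 2 by the change (amino in place of hydroxy on an aromatic carbon). The surroundings of the place are the same in both cases, so this is the same change as that from compound 1 to compound 3. Compound 2 already stands at a higher number than compound 1, and since the earlier instance of this change gave an at least 22-fold higher number from compound 1 to compound 3 (1.34 log units; beyond the scatter), a step of similar or larger size is expected, namely a 5.9-fold higher number from compound 2 to compound 4 (0.77 log units; beyond the scatter), which would carry compound 4 past the limit of the assay. For compound 4 the number is estimated at 300 ug/mL, with an expected range from 100 ug/mL to 1500 ug/mL, most likely reported only as a limit.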

Compound 4, concentration for half-maximal effect: > 100 ug/mL
Compound 4: no number, only a limit; the forecaster's own chance of this, stated with the estimate: 85%; the middle value is on the limit's open side.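

Compound 4 gives > 100 ug/mL in this assay, a limit of the assay and not a number. On the core of compound 2, amino in place of hydroxy on an aromatic carbon brings an at least 1.9-fold higher number from compound 2 to compound 4 (0.29 log units; that floor lies within the scatter), so the change points the same way as on the core of compound 1, although this floor alone does not separate the step from the scatter. The result shows that neither core gives a lower number with amino than with hydroxy, but it does not show whether the change has the same size on the two cores: the same change on two cores in this assay, an at least 22-fold higher number (1.34 log units; beyond the scatter) from compound 1 to compound 3 and an at least 1.9-fold higher number (0.29 log units; that floor lies within the scatter) from compound 2 to compound 4; the limit leaves it open whether they differ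

The compounds shown leave open how each core would respond to other groups on that aromatic carbon, such as a methoxy group, a chlorine atom or a thiol, any of which might give a measurable number in place of a limit. They also leave open what a carboxylic acid or a longer chain in place of the hydroxymethyl group would do on either core.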